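The source may report more compounds than this note shows. Statements on the series, on what has been measured and on what is new or still open speak of the compounds shown alone.

Compound 1 `CCCCNC(=O)/C=C/c1c(/C=C/c2ccc(OC)cc2)cc(OC)cc1OC`: 1880 nM
Compound 2 `COc1ccc(/C=C/c2cc(OC)cc(OC)c2/C=C/C(=O)N2CCCCC2)cc1`: 10600 nM
Compound 3 `CCCCCCNC(=O)/C=C/c1c(/C=C/c2ccc(OC)cc2)cc(OC)cc1OC`: not yet measured

Going by the values given here, in a functional assay on A549 cells (Homo sapiens) for inhibition, read by MTT assay, with a stated time of 48 h (on this read-out higher numbers stand for weaker inhibition and lower numbers for stronger inhibition), compound 2 gives 10600 nM, the higher of the two numbers so far. Compound 3 differs from it by hexylamino in place of piperidin-1-yl on a carbonyl carbon. Among the compounds with values here, the one measured step that bears on this is a 5.6-fold higher number from compound 1 to compound 2 (0.75 log units; beyond the scatter), where piperidin-1-yl replaced butylamino, a modest step beyond the scatter. Read in reverse, it suggests a step of similar size toward a lower number in this assay, although no measured compound carries hexylamino. That expectation amounts to a 4.2-fold lower number from compound 2 to compound 3 (0.63 log units; beyond the scatter). For compound 3 the estimated value is 2500 nM, with an expected range of 800 nM to 7000 nM.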

Compound 3, half-maximal inhibitory concentration: 6230 nM
Estimate against measurement, compound 3: 2.5-fold (0.40 log units) below, and the stated range covers the measured number.
By their numbers in this assay, from the lowest: compound 1; then compounds 3 and 2 (each within the scatter of the next).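

Swapping the ring for an open chain does not by itself restore the number of compound 1: in this assay, hexylamino and piperidin-1-yl on this carbonyl carbon cannot be told apart, with a 1.7-fold lower number from compound 2 to compound 3 (0.23 log units; within the scatter). Keeping the amide hydrogen is not enough either, since adding ethyl to the butyl chain gives a 3.3-fold higher number from compound 1 to compound 3 (0.52 log units; beyond the scatter), so chain length matters here. The data offer no explanation for either step.

Still open, on these data alone, is how a shorter chain such as ethylamino would read. Diethylamino would test an open chain without the amide hydrogen.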